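The source may hold more compounds than are shown below. What is called first, only, known or untested is meant among the compounds shown, and "the series" means these compounds.

For the measured compounds named here, compound 1 `FC(F)(F)c1ccccc1OC1CCN(c2ccc(-c3nnco3)nn2)CC1` is the stronger of the two compounds measured so far. In an assay on microsomes from liver for inhibition of acyl-CoA desaturase 1 (Rattus norvegicus) (a lower number here means a stronger inhibitor, a higher number a weaker inhibitor), compound 1 gives 22 nM, whereas compound 2 `Cc1ccc(OC2CCN(c3ccc(-n4ccnc4)nn3)CC2)cc1` gives 527 nM in this assay, a gap well beyond the usual scatter. Compound 3 `FC(F)(F)c1ccccc1OC1CCN(c2ccc(-n3ccnc3)nn2)CC1` has not yet been measured. It differs from compound 1 in one place: 1H-imidazol-1-yl in place of 1,3,4-oxadiazol-2-yl on an aromatic carbon. Compound 2 also carries the 1H-imidazol-1-yl group, but its other end differs from compound 1 as well, so the two measured values alone cannot separate the part played by each change. Still, the high number of compound 2 527 nM points toward a weaker result once the imidazole is in place. Compound 3 is therefore expected to give a higher number than compound 1, with a step of a 5.0-fold higher number from compound 1 to compound 3 (0.70 log units; beyond the scatter) that should lie beyond the scatter. The estimate for compound 3 is 110 nM, within a range from 30 nM to 400 nM.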

Compound 3, half-maximal inhibitory concentration: 4 nM
Compound 3: middle estimate off by 28-fold (1.44 log units), on the high side, outside the stated range (below it).
By their numbers in this assay, from the lowest: compound 3; then compound 1; then compound 2.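

In this assay, replacing the 1,3,4-oxadiazol-2-yl group with 1H-imidazol-1-yl on this aromatic carbon, para to a large group, gives a 5.5-fold lower number from compound 1 to compound 3 (0.74 log units; beyond the scatter). This shows that, with the rest of the molecule unchanged, the imidazole is linked to stronger inhibition rather than weaker, and that the 1H-imidazol-1-yl group alone does not bring a high number, since compound 3 carries it and gives 4 nM. Nothing available explains why this change lowers the number.

This single matched pair leaves open whether the same swap would lower the number with a different group at the other end of the molecule. It also leaves open how an open-chain amine or a carboxylic acid would fare in place of the five-membered ring.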